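Chloro in place of methoxy: outlook for compound 3

This account rests on a few compounds, and the source may have more. Where it says the series, first, only, none or still open, it means among the compounds named here.

Two compounds have numbers in a functional assay on EA.hy 926 cells (Homo sapiens) for cytotoxicity, read by MTT assay, with stated times of 24 h and 12 h, tested at 100 uM; a higher number here means a stronger effect of the compound at the concentration tested, a lower number a weaker effect. Compound 1 `CCOC(=O)/C=C/c1cc(OC)ccc1OC(=O)c1nc(C)c(C)nc1C` gives 46.2% there, and compound 2 `Cc1nc(C)c(C(=O)Oc2ccc(/C=C/C(=O)O)cc2O)nc1C` gives 601%. Compound 1 thus stands lowest of the two, with compound 2 far higher, beyond the scatter. Compound 3 `CCOC(=O)/C=C/c1cc(Cl)ccc1OC(=O)c1nc(C)c(C)nc1C` follows from compound 1 by chloro in place of methoxy on an aromatic carbon. Among the compounds with values here, no measured pair shows this change, so its size is unknown; the step is expected to be small, a number 3.8 percentage points higher from compound 1 to compound 3 (within the scatter), with no direction beyond the scatter. Compound 3 is accordingly estimated at 50% in this assay, within a range from 20% to 100%.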

Compound 3, a percentage reported as activity, at one concentration (the size of the read-out at that concentration, not a potency): 11%
Beside the measured number, compound 3's estimate is 39 percentage points above it; the measured number lies below the stated range.
By their numbers in this assay, from the lowest: compound 3; then compound 1; then compound 2.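

Chloro in place of methoxy, meta to a 2-(ethoxycarbonyl)ethenyl group and para to a large group, gives a number 35.2 percentage points lower from compound 1 to compound 3 (beyond the scatter) in this assay and so marks this position as sensitive to its substituent in this read-out. Compound 1 and compound 2 differ in more than one place and could not show this. No evidence at hand bears on the reason for this step.

Open, on these data alone, is how an amine, a hydroxyl or a bromo at this position would read. Also open, as far as these compounds go, is whether the step persists with a carboxylic acid in place of the ethyl ester.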